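Exchanging a Dichlorophenyl Amide for an Oxazole Amide

The source may report more compounds than this note shows. Statements on the series, on what has been measured and on what is new or still open speak of the compounds shown alone.

Two amides built on one shared core have been measured in an assay on LtK cells with ATP-sensitive inward rectifier potassium channel 11 (Homo sapiens) as the target; a lower number here means that less compound is needed, a higher number that more compound is needed for the effect. Compound 1 `O=C(Nc1c(C(O)(C(F)(F)F)C(F)(F)F)ccc2ccccc12)c1cccc(Cl)c1` gives 98 nM. Compound 2 `O=C(Nc1c(C(O)(C(F)(F)F)C(F)(F)F)ccc2ccccc12)c1ccc(Cl)c(Cl)c1` gives 194 nM, the higher of the two numbers, yet the step of a 2.0-fold higher number from compound 1 to compound 2 (0.30 log units; within the scatter) lies within the scatter, so the two compounds cannot be told apart on this evidence. Compound 3 `O=C(Nc1c(C(O)(C(F)(F)F)C(F)(F)F)ccc2ccccc12)c1cnco1` has not been measured. It differs from compound 2 in one place: 1,3-oxazol-5-yl in place of 3,4-dichlorophenyl on a carbonyl carbon. Going by the values given here, no measured step bears directly on this change; the only step available, a 2.0-fold higher number from compound 1 to compound 2 (0.30 log units; within the scatter), adds a chloro group to the same six-membered ring, whereas here that whole ring is exchanged for a five-membered ring with 2 hetero atoms. Such an exchange is larger than anything measured here, so the expected step of a 3.6-fold higher number from compound 2 to compound 3 (0.56 log units; beyond the scatter) is toward a higher number, with wide uncertainty. Compound 3 is therefore estimated at 700 nM, within a range from 150 nM to 3500 nM.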

Compound 3, half-maximal effective concentration: 24 nM
Compound 3: middle estimate off by 29-fold (1.46 log units), on the high side; the whole stated range lies above it.
By their numbers in this assay, from the lowest: compound 3; then compounds 1 and 2 (each within the scatter of the next).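

In this assay, putting 1,3-oxazol-5-yl in place of 3,4-dichlorophenyl on the carbonyl carbon gives an 8.1-fold lower number from compound 2 to compound 3 (0.91 log units; beyond the scatter), and putting it in place of 3-chlorophenyl gives a 4.1-fold lower number from compound 1 to compound 3 (0.61 log units; beyond the scatter). This position therefore does not depend on a chlorinated six-membered ring of carbon only: a smaller five-membered ring with 2 hetero atoms and 2 hydrogen-bond acceptors also works here, and less compound is needed for the effect. No measurement at hand explains this drop in the number.

The compounds shown leave open whether the oxazole ring itself matters or whether losing the chlorophenyl ring is enough. They also leave open how a thiazole, a furan or a pyridine ring would compare, and what an amine or a carboxylic acid on the oxazole ring would do.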